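Acyl thiourea series: benzodioxinyl to dimethoxyphenyl on the carbonyl

The source may report more compounds than this note shows. Statements on the series, on what has been measured and on what is new or still open speak of the compounds shown alone.

Measured so far:
compound 1 `O=C(NC(=S)Nc1cccc(-c2nc3ccccc3[nH]2)c1)c1ccccc1` in a functional assay on MDA-MB-231 cells (Homo sapiens) for cytotoxicity, read by WST assay, with a stated time of 48 h; a lower number here means a stronger inhibitor, a higher number a weaker inhibitor: > 10000 nM.
compound 2 `O=C(NC(=S)Nc1cccc(-c2nc3ccccc3[nH]2)c1)c1ccc2c(c1)OCCO2` in this assay: 400 nM.

The value of compound 1 in this assay is a limit of the assay, not a number (the limit of > 10000 nM in this assay, at which 1 of the 2 values shown sits). Compound 2 gives the only number shown, and the step of an at least 25-fold lower number from compound 1 to compound 2 (1.39 log units; beyond the scatter) is the only measured step in the set.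

Compound 3 `COc1ccc(C(=O)NC(=S)Nc2cccc(-c3nc4ccccc4[nH]3)c2)cc1OC` differs from compound 2 by 3,4-dimethoxyphenyl in place of 2,3-dihydro-1,4-benzodioxin-6-yl on a carbonyl carbon. The measured step bears on it only loosely: it shows that the group on the carbonyl carbon can move the value strongly, but it compares phenyl with the benzodioxinyl group, not two oxygen-bearing aryls. Within the data shown here, no measured pair shows the dimethoxyphenyl against the benzodioxinyl group.

For compound 3 a step of a 1.3-fold higher number from compound 2 to compound 3 (0.10 log units; within the scatter) is expected, within the scatter. Compound 3 is therefore estimated at 500 nM in this assay, with a range from 150 nM to 2000 nM.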

Compound 3, half-maximal inhibitory concentration: > 10000 nM
Compound 3: no number, only a limit; the forecaster's own chance of this, stated with the estimate: 10%; middle value at least 20-fold (1.30 log units) away from the limit.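

Exchanging 2,3-dihydro-1,4-benzodioxin-6-yl for 3,4-dimethoxyphenyl on the carbonyl carbon in this assay gives an at least 25-fold higher number from compound 2 to compound 3 (1.39 log units; beyond the scatter), so the oxygen-bearing aryl groups on this carbon are not interchangeable, although the two groups match in heavy atoms and hydrogen-bond acceptors. Compound 3 gives > 10000 nM, which is a limit of the assay and not a number, so the step from compound 1 to compound 3 cannot be read. Among the three compounds, only the 2,3-dihydro-1,4-benzodioxin-6-yl group of compound 2 gives a number rather than the limit: the limit of > 10000 nM in this assay, at which 2 of the 3 values shown sit.

On these data alone, whether the closed ring is itself required remains open. A 1,3-benzodioxol-5-yl group or a phenyl carrying a single methoxy group on the carbonyl carbon would bear on that question.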